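A Propyl Chain in Place of Methoxy on the Ring

This account rests on a few compounds, and the source may have more. Where it says the series, first, only, none or still open, it means among the compounds named here.

Of the compounds shown here, three sharing one core have been tested in a functional assay on the whole organism for inhibition, with Rattus norvegicus as the target, at a dose of 10 mg/kg by the oral route; a lower number here means a weaker effect, a higher number a stronger effect of the compound at the dose given. Compound 1 `CSc1ccc(C(=O)Nc2nn[nH]n2)nc1` gives 29%. Compound 2 `COc1cccc(C(=O)Nc2nn[nH]n2)n1` gives 58%, and compound 3 `Cc1cccnc1C(=O)Nc1nn[nH]n1` gives 69%. On these numbers compound 2 stands in the middle: its value lies below that of compound 3 and above that of compound 1, with both gaps beyond the usual scatter. Compound 4 `CCCc1cccc(C(=O)Nc2nn[nH]n2)n1` has not yet been measured. It differs from compound 2 in one place: propyl in place of methoxy on an aromatic carbon. Among the compounds with values here, no pair of the measured compounds differs in only one place, so the size of such a change cannot be read from them. The expected change in this assay is a number 3 percentage points lower from compound 2 to compound 4 (within the scatter), a step that would stay within the scatter. Compound 4 is estimated at 55%, with a range from 30% to 80%.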

Compound 4, a percentage reported as inhibition, in the whole organism at one dose (the size of the read-out at that dose, not a potency): 38%
Beside the measured number, compound 4's estimate is 17 percentage points above it; low and high end bracket the measured number.
By their numbers in this assay, from the lowest: compounds 1 and 4 (each within the scatter of the next); then compound 2; then compound 3.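

In this assay, the group on this aromatic carbon next to the ring nitrogen clearly matters: replacing methoxy with propyl gives a number 20 percentage points lower from compound 2 to compound 4 (beyond the scatter). Within the data shown here, this is the first direct one-place comparison, and it shows that the result at this position depends on which of these two groups is present. Nothing measured here explains the loss of effect.

Among these compounds, the single step cannot separate removing the oxygen from adding a longer carbon chain. Ethoxy or ethyl at this position would help distinguish these two changes.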